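Ethoxy Added Where Chloro and Methyl Gave Only Limits

This account rests on a few compounds, and the source may have more. Where it says the series, first, only, none or still open, it means among the compounds named here.

Compound 1 `FC(F)(F)c1ccc(CSc2nc(Nc3ccccc3)c3ccccc3n2)cc1` is the only one of the three measured compounds for which a real number exists. In a functional assay on MCF7 cells (Homo sapiens) for cytotoxicity, read by MTT assay, with a stated time of 72 h (on this read-out lower numbers stand for stronger inhibition and higher numbers for weaker inhibition), compound 1 gives 44000 nM. Compound 2 `FC(F)(F)c1ccc(CSc2nc(Nc3ccccc3Cl)c3ccccc3n2)cc1` carries chloro in place of hydrogen on an aromatic carbon; in this assay compound 2 reaches only a limit of the assay, > 50000 nM. Compound 3 `Cc1ccc(Nc2nc(SCc3ccc(C(F)(F)F)cc3)nc3ccccc23)cc1` carries methyl in place of hydrogen on an aromatic carbon; in this assay compound 3 likewise gives a limit, > 50000 nM. Both sit at the limit of > 50000 nM in this assay, at which 2 of the 3 values shown sit, so the step between them is a step that the two limits leave unreadable from compound 2 to compound 3.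

Compound 4 `CCOc1ccc(Nc2nc(SCc3ccc(C(F)(F)F)cc3)nc3ccccc23)cc1` differs from compound 1 by ethoxy in place of hydrogen on an aromatic carbon. The two measured changes on that ring read as an at least 1.1-fold higher number from compound 1 to compound 2 (0.05 log units; that floor lies within the scatter) and an at least 1.1-fold higher number from compound 1 to compound 3 (0.05 log units; that floor lies within the scatter), each a floor that may hide a larger weakening, so for compound 4 a small rise in number, quite possibly ending at the limit, is expected. The expected step is a 1.4-fold higher number from compound 1 to compound 4 (0.13 log units; within the scatter). Compound 4 is estimated at 60000 nM, within 25000 nM to 150000 nM.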

Compound 4, half-maximal inhibitory concentration: > 50000 nM
Compound 4 was reported as a limit; the forecaster's own chance of this, stated with the estimate: 60%; the middle value does not contradict the limit.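

Ethoxy in place of hydrogen, para to a large group, gives an at least 1.1-fold higher number from compound 1 to compound 4 (0.05 log units; that floor lies within the scatter), so in this assay this change shows no sign of stronger inhibition than the plain phenyl of compound 1. Compound 4 reaches only a limit of the assay, as compound 2 with its chloro and compound 3 with its methyl do, and the steps among these three compounds cannot be read. Every change on this ring shown so far therefore ends at the same limit: the limit of > 50000 nM in this assay, at which 3 of the 4 values shown sit.

Going by these compounds, how far beyond that limit compound 2, compound 3 and compound 4 lie remains unknown, which hides any order among them. Also open, on these data alone, is whether an amine or a carboxylic acid on this ring would give a lower number than compound 1, at 44000 nM.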